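The source may report more compounds than this note shows. Statements on the series, on what has been measured and on what is new or still open speak of the compounds shown alone.

Measured in an ADME assay on TZM-b1 cells (Homo sapiens) for cytotoxicity, read by XTT assay, with a stated time of 3 days; a lower number here means that less compound is tolerated, a higher number that more compound is tolerated:
- Compound 1 `Cc1nc(C(NC(=O)C(=O)Nc2ccc(F)c(Cl)c2)C2CCCCN2)sc1CO`: in this assay compound 1 gives only a limit, > 77800 nM.
- Compound 2 `CC(=O)c1ccc(NC(=O)C(=O)NC(c2nc(C)c(CO)s2)C2CCCCN2)cc1`: in this assay compound 2 gives only a limit, > 86000 nM.
- Compound 3 `Cc1nc(C(NC(=O)C(=O)NC2CCCCCC2)C2CCCCN2)sc1CCO`: in this assay compound 3 gives only a limit, > 88000 nM.

Compound 3 stands at a limit of this assay, and the two other values shown for the series are limits as well (the limit of > 77800 nM in this assay, at which 1 of the 3 values shown sits, (the limit of > 86000 nM in this assay, at which 1 of the 3 values shown sits), (the limit of > 88000 nM in this assay, at which 1 of the 3 values shown sits)). For the measured compounds named here, the one step between measured compounds, a step that the two limits leave unreadable from compound 1 to compound 2, is unreadable because both ends are limits, so no measured step gives a size to work from.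

Compound 4 `Cc1nc(C(NC(=O)C(=O)NC2CCCCCC2)C2CCCCN2)sc1CO` differs from compound 3 by hydroxy in place of hydroxymethyl on a saturated chain carbon bound to an aromatic carbon. Going by the values given here, no measured step bears on this change directly; what the series shows is that no compound has yet produced a number in this assay. The expectation is therefore that the step from compound 3 to compound 4, a number no higher from compound 3 to compound 4 (the limit leaves the size open), is none beyond the scatter, and that compound 4 is most likely to come back as a limit again. As a working estimate, compound 4 is expected to give about 88000 nM in this assay, within a range of 40000 nM to 200000 nM.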

Compound 4, half-maximal cytotoxic concentration: > 90000 nM
Compound 4: no number, only a limit; the forecaster's own chance of this, stated with the estimate: 85%; middle value at least 1.0-fold (0.00 log units) from the limit.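

In this assay compound 4 gives only a limit, > 90000 nM. Its steps from compound 1, compound 2 and compound 3 cannot be read, as all four values are limits. The compounds shown leave open the concentration at which any of them becomes cytotoxic in this assay, and with it whether either change of group shifts tolerance at all.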